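Chain variation on the core: acetyl in place of ester

This account rests on a few compounds, and the source may have more. Where it says the series, first, only, none or still open, it means among the compounds named here.

The series shares the core of compound 1 `COC(=O)CCCc1onc(NS(=O)(=O)c2ccc(C(C)(C)C)cc2)c1Sc1cccc(OC)c1`, and in an assay on COS-7 cells for displacement of a labelled ligand from Endothelin receptor type B (Sus scrofa) (on this read-out lower numbers stand for stronger inhibition and higher numbers for weaker inhibition), compound 1 gives 310 nM. Compound 2 `COc1cccc(Sc2c(NS(=O)(=O)c3ccc(C(C)(C)C)cc3)noc2C)c1` carries a hydrogen where compound 1 carries the longer chain; in this assay compound 2 gives 300 nM, the lower of the two numbers, although the step of a 1.0-fold lower number from compound 1 to compound 2 (0.01 log units; within the scatter) keeps it within the scatter of compound 1.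

Compound 3 `COc1cccc(Sc2c(NS(=O)(=O)c3ccc(C(C)(C)C)cc3)noc2CCCC(C)=O)c1` is not yet measured. It differs from compound 2 by 2-acetylethyl in place of hydrogen on a saturated chain carbon bound to an aromatic carbon; the same difference, cut one bond further out, reads methyl to 3-acetylpropyl. Among the compounds with values here, the one measured step that bears on this place is the step from compound 1 to compound 2, where removing 2-(methoxycarbonyl)ethyl from the saturated chain carbon gave a 1.0-fold lower number from compound 1 to compound 2 (0.01 log units; within the scatter), within the scatter. Compound 3 reinstates a chain of comparable length at the same place, with a ketone carbonyl in place of the ester. No shift beyond the scatter is therefore expected in this assay, so the step from compound 2 to compound 3 is estimated as no change at the digits printed from compound 2 to compound 3 (within the scatter). Compound 3 is estimated at 300 nM, with a range from 150 nM to 650 nM.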

Compound 3, half-maximal inhibitory concentration: 400 nM
Compound 3: middle estimate off by 1.3-fold (0.12 log units), on the low side, and the stated range covers the measured number.
By their numbers in this assay, from the lowest: compounds 2, 1 and 3 (each within the scatter of the next).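

Working notes on the chain position: at the saturated chain carbon bound to an aromatic carbon, 2-acetylethyl in place of hydrogen gives a 1.3-fold higher number from compound 2 to compound 3 (0.12 log units; within the scatter) in this assay, so a chain ending in a ketone carbonyl reads the same, within the scatter, as the bare methyl of compound 2. Within the data shown here, the earlier pair only removed the whole ester chain, whereas the change at the chain end itself, methyl in place of methoxy on a carbonyl carbon, gives a 1.3-fold higher number from compound 1 to compound 3 (0.11 log units; within the scatter) and is the first reading of that end of the chain. No supporting data bear on why these three compounds sit so close together.

Whether a carboxylic acid, an amine or a longer chain at this place would give a step beyond the scatter remains open, since the hydrogen, ester and ketone variants shown do not separate from one another. Also open, from the compounds shown here alone, is whether this flat reading at the chain would hold with a different group on the sulfonamide aryl ring or with the 3-methoxyphenyl thioether replaced by another group.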